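Chain extension from compound 3 to compound 4

The source may hold more compounds than are shown below. What is called first, only, known or untested is meant among the compounds shown, and "the series" means these compounds.

Among the measured compounds shown here, in a functional assay on SK-HEP1 cells (Homo sapiens) for inhibition, read by MTT assay, with a stated time of 72 h (on this read-out higher numbers stand for weaker inhibition and lower numbers for stronger inhibition), compound 3 `Nc1nc2cc(-c3nn(CCCCC(=O)NO)c4ncnc(N)c34)ccc2o1` gives 6400 nM, the lowest number of the three measured so far. Compound 1 `Nc1nc2cc(-c3nn(CCCCCCCCCC(=O)NO)c4ncnc(N)c34)ccc2o1` gives 14100 nM. Compound 2 `Nc1ncnc2c1c(-c1cnc3[nH]ccc3c1)nn2CCCCCCC(=O)NO` gives 14700 nM, but it differs from compound 3 in more than one place and offers no clean comparison.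

Compound 4 `Nc1nc2cc(-c3nn(CCCCCC(=O)NO)c4ncnc(N)c34)ccc2o1` carries (hydroxycarbamoyl)methyl in place of hydroxycarbamoyl on a saturated chain carbon, four bonds along the chain from an aromatic nitrogen.

For the measured compounds named here, only one measured step bears on this change: a 2.2-fold lower number from compound 1 to compound 3 (0.34 log units; beyond the scatter). That step is modest, and it spans the whole 5-(hydroxycarbamoyl)pentyl difference, of which the new change covers only a small part, running the opposite way. A single step fixes no trend, and the data do not show how the numbers behave at intermediate chain lengths. A slight shift towards a higher number is therefore expected, with no step beyond the scatter: a 1.2-fold higher number from compound 3 to compound 4 (0.07 log units; within the scatter). The estimate for compound 4 is 7500 nM, with an expected range of 3000 nM to 15000 nM.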

Compound 4, half-maximal inhibitory concentration: 3080 nM
Compound 4: middle estimate off by 2.4-fold (0.39 log units), on the high side; measured number inside the range.
By their numbers in this assay, from the lowest: compound 4; then compound 3; then compounds 1 and 2 (each within the scatter of the next).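

In this assay, among the compounds shown here, lengthening the chain does not raise the number, as the one earlier step suggested it might: the change runs a 2.1-fold lower number from compound 3 to compound 4 (0.32 log units; beyond the scatter), so a shorter chain does not always give a lower number. Compound 4 also sits well under the long-chain analogue, with a 4.6-fold lower number from compound 1 to compound 4 (0.66 log units; beyond the scatter), so along these three compounds the number falls and then rises, and compound 3 goes against any simple rule that shorter is better. No measurement on hand accounts for this dependence on chain length.

Still open, going by these compounds, is how the numbers run at chain lengths between those of compound 4 and compound 1, and on chains shorter than that of compound 3. Also open, on these data alone, is whether a carboxylic acid at the chain end, in place of hydroxycarbamoyl, would hold numbers at this level.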